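Aryl swap on the ring amine nitrogen, compound 2 to compound 4

This account rests on a few compounds, and the source may have more. Where it says the series, first, only, none or still open, it means among the compounds named here.

The series is compared in a functional assay on the whole organism for inhibition, with Mus musculus as the target, at a dose of 25 mg/kg by the oral route; a higher number here means more inhibition at the dose given (going by the name of the read-out), a lower number less inhibition. Compound 1 `c1ccc(N2CCN(CCCCCOc3ccc4c(c3)CCC4)CC2)cc1` gives 25% in this assay. Compound 2 `Fc1cccc(N2CCN(CCCOc3ccc4c(c3)CCC4)CC2)c1` gives 42%. Compound 3 `COc1ccccc1N1CCN(CCCCOc2ccc3c(c2)CCC3)CC1` gives 42%. Compound 2 stands level with compound 3 at the digits shown, the two together giving the highest of the three numbers, while compound 1 lies furthest from compound 2, its number lower by more than the scatter. Among the measured compounds shown here, no two measured compounds differ in only one place, so no single measured step is available to calibrate the change now in question.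

Compound 4 `CC(=O)c1ccc(N2CCN(CCCOc3ccc4c(c3)CCC4)CC2)cc1` differs from compound 2 thus: 4-acetylphenyl in place of 3-fluorophenyl on an amine nitrogen in a ring.

With no measured step of this kind in hand, the step from compound 2 to compound 4 in this assay is expected to stay within the scatter, and a number 6 percentage points lower from compound 2 to compound 4 (within the scatter) is the estimated size. Compound 4 is therefore expected to give about 36% in this assay, estimated to lie between 14% and 58%.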

Compound 4, a percentage reported as inhibition, in the whole organism at one dose (the size of the read-out at that dose, not a potency): 0%
For compound 4 the middle estimate is 36 percentage points above the measured one, and the stated range ends above it.
By their numbers in this assay, from the lowest: compound 4; then compound 1; then compounds 2 and 3 (each within the scatter of the next).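

Among the compounds shown here, the aryl group on the ring amine nitrogen is the first place where a single change can be read, and the change is far from neutral: in this assay, 4-acetylphenyl in place of 3-fluorophenyl gives a number 42 percentage points lower from compound 2 to compound 4 (beyond the scatter). This position can therefore separate a clear read-out at this dose from none, which compounds 1, 2 and 3 could not show, as no two of them differ in only one place. No evidence at hand bears on the origin of this drop.

Still open, from the compounds shown here alone, is whether the loss belongs to the acetyl group itself or would also follow other groups on this phenyl ring, such as a nitrile or an amide. For the compounds shown here, the single step also leaves open whether the same swap would carry the same size on a longer chain, as in compound 1 or compound 3.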